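The compounds below may be only part of what the source reports. "The series", "measured", "known", "first", "only" and "open" are said of these compounds alone.

Four compounds share one core here: compound 1 (`NC(=O)Nc1sc(-c2ccccc2)cc1C(=O)NC1CCNCC1`), compound 2 (`CNCCNC(=O)c1cc(-c2ccccc2)sc1NC(N)=O`), compound 3 (`NC(=O)Nc1sc(-c2ccccc2)cc1C(=O)Nc1ccccc1`) and the still unmeasured compound 4 (`NCCNC(=O)c1cc(-c2ccccc2)sc1NC(N)=O`). Among the compounds with values here, in a functional assay on HT-29 cells (Homo sapiens) (a lower number here means that less compound is needed, a higher number that more compound is needed for the effect), compound 2 gives 580 nM as the only number so far. Compound 1 has no result ("not determined" (no result reported)) and neither does compound 3 ("not determined" (no result reported)), so compound 3 offers no number to start from. The change to compound 4 is 2-aminoethyl in place of phenyl on an amide-type nitrogen and amounts to 2-aminoethyl in place of phenyl on an amide-type nitrogen. Within the data shown here, no measured step exists to guide the expectation, so in this assay compound 4 is expected to sit within the scatter of compound 2 (580 nM), its closest measured relative, with no firm direction. Compound 4 is expected at 500 nM (estimated range 150 nM to 1700 nM).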

Compound 4, half-maximal effective concentration: 960 nM
Compound 4: middle estimate off by 1.9-fold (0.28 log units), on the low side; the range from low to high includes it.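

In this assay, hydrogen in place of methyl on the amine nitrogen gives a 1.7-fold higher number from compound 2 to compound 4 (0.22 log units; within the scatter), so at this nitrogen the two compounds cannot be told apart. The change from phenyl to 2-aminoethyl on the amide-type nitrogen cannot be read, as compound 3 and compound 1 have no number to compare.

Still open, from the compounds shown here alone, is how a larger group on this amine nitrogen, such as ethyl, would read. Going by these compounds, a longer chain than 2-aminoethyl, or a carboxylic acid in place of the amine, also remains untested here. No supporting data on hand offer an explanation for this result.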